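This account rests on a few compounds, and the source may have more. Where it says the series, first, only, none or still open, it means among the compounds named here.

Three measured compounds share one core. Compound 1 `O=c1c2ccccc2[se]n1-c1nc(SCc2ccccc2)n[nH]1` is the unsubstituted member. In an ADME assay on L929 cells (Mus musculus) for antiproliferative activity, read by CCK-8 assay, with a stated time of 48 h (on this read-out higher numbers stand for weaker inhibition and lower numbers for stronger inhibition), compound 1 gives > 50000 nM, which is a limit of the assay. Compound 2 `Cc1ccccc1CSc1n[nH]c(-n2[se]c3ccccc3c2=O)n1` carries a methyl on an aromatic carbon, and in this assay compound 2 gives 15600 nM. Compound 3 `Cc1ccc(CSc2n[nH]c(-n3[se]c4ccccc4c3=O)n2)cc1` carries its methyl on a different aromatic carbon. In this assay compound 3 gives > 50000 nM, again a limit. Compound 3 thus stands at the limit of > 50000 nM in this assay, at which 2 of the 3 values shown sit, sharing that position with compound 1. The readable steps are an at least 3.2-fold lower number from compound 1 to compound 2 (0.50 log units; beyond the scatter) and an at least 3.2-fold higher number from compound 2 to compound 3 (0.50 log units; beyond the scatter); the pair of compound 1 and compound 3 shows only two limits.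

Compound 4 `CC(C)Sc1n[nH]c(-n2[se]c3ccccc3c2=O)n1` differs from compound 3 by isopropyl in place of 4-methylbenzyl on a sulfur. Neither readable step bears on this change directly, since both move a methyl between aromatic carbons while the benzyl portion itself stays; the change in compound 4 removes that portion altogether. Compound 4 is expected to remain near the limit, estimated at 40000 nM, with a range from 8000 nM to 100000 nM. The step of an at least 1.2-fold lower number from compound 3 to compound 4 (0.09 log units; that floor lies within the scatter) is expected to be unreadable against a limit.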

Compound 4, half-maximal inhibitory concentration: 37100 nM
Compound 4: the middle estimate sits 1.1-fold (0.03 log units) above what was measured, and the stated range covers the measured number.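

Replacing 4-methylbenzyl on the sulfur with isopropyl, which removes the aromatic ring, gives in this assay an at least 1.3-fold lower number from compound 3 to compound 4 (0.12 log units; that floor lies within the scatter), and replacing benzyl gives an at least 1.3-fold lower number from compound 1 to compound 4 (0.12 log units; that floor lies within the scatter), so neither step shows a change beyond the scatter. Replacing 2-methylbenzyl gives a 2.4-fold higher number from compound 2 to compound 4 (0.38 log units; beyond the scatter), so among the sulfur groups shown 2-methylbenzyl alone stands apart, and an aromatic ring on this sulfur does not by itself bring the lower number. Compound 1 and compound 3 keep their aromatic rings and still remain at a limit of the assay: the limit of > 50000 nM in this assay, at which 2 of the 4 values shown sit.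

The compounds shown leave open whether a straight butyl chain or a chain ending in an amine on this sulfur would move the number. They also leave open whether a chlorine in place of the methyl of 2-methylbenzyl would keep the lower number.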